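The source may report more compounds than this note shows. Statements on the series, on what has been measured and on what is new or still open speak of the compounds shown alone.

Compound 1 `O=C(c1ccc2c(c1)OCCO2)C1CCN(Cc2coc(-c3ccccc3F)n2)CC1` has been run through an ADME assay on HEK293 cells (Homo sapiens) for cytotoxicity, read by MTT assay, with a stated time of 36 h; on this read-out higher numbers stand for weaker inhibition and lower numbers for stronger inhibition. In this assay compound 1 gives > 150 ug/mL, which is a limit of the assay rather than a number. Among the compounds with values here, its one measured neighbour, compound 2 `Cc1ccc(-c2nc(CN3CCC(C(=O)c4ccc5c(c4)OCCO5)CC3)co2)cc1`, carries a 4-methylphenyl in place of the 2-fluorophenyl. In this assay compound 2 gives > 150 ug/mL, again a limit. The step that the two limits leave unreadable from compound 1 to compound 2 therefore cannot be read; what the two values share is the limit of > 150 ug/mL in this assay, at which 2 of the 2 values shown sit. Compound 3 `O=C(c1ccc2c(c1)OCCO2)C1CCN(Cc2coc(-c3ccoc3)n2)CC1` is the unmeasured partner: furan-3-yl in place of 2-fluorophenyl on an aromatic carbon. Within the data shown here, no measured step covers a furan-3-yl, and the only step known sits at the limit on both ends, so no step beyond the scatter is expected from compound 1 to compound 3, and compound 3 is expected to end at the limit as well. The expected step of a number no higher from compound 1 to compound 3 (the limit leaves the size open) puts compound 3 at an estimated 150 ug/mL, within 75 ug/mL to 300 ug/mL.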

Compound 3, half-maximal inhibitory concentration: > 150 ug/mL
Compound 3 was reported as a limit (the forecaster's own chance of this, stated with the estimate: 85%); the middle value sits exactly at the limit.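

Compound 3 also gives only a limit, so no step from compound 1 or compound 2 to compound 3 can be read: the limit of > 150 ug/mL in this assay, at which 3 of the 3 values shown sit.

The compounds shown leave open whether 2-fluorophenyl, 4-methylphenyl and furan-3-yl differ at all in cytotoxicity; none of the three compounds gives an actual number.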